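This account rests on a few compounds, and the source may have more. Where it says the series, first, only, none or still open, it means among the compounds named here.

Compound 1 `C=C(c1cc(OC)c(OC)c(OC)c1)c1ccc(OC)cc1NC(=O)CO` gives 20 nM
Compound 2 `C=C(c1cc(OC)c(OC)c(OC)c1)c1ccc(OC)cc1NC(=O)CN` gives 40 nM
Compound 3 `C=C(c1cc(OC)c(OC)c(OC)c1)c1ccc(OC)cc1NC(=O)CNC` gives 100 nM

In a functional assay on A549 cells (Homo sapiens) for antiproliferative activity, read by MTT assay, with a stated time of 48 h (a lower number here means a stronger inhibitor, a higher number a weaker inhibitor), compound 3 stands at 100 nM as the highest of the three numbers. Compound 4 `C=C(c1cc(OC)c(OC)c(OC)c1)c1ccc(OC)cc1NC(=O)CN(C)C` awaits measurement. It differs from compound 3 by methyl in place of hydrogen on an amine nitrogen with methyl in place of hydrogen on an amine nitrogen. For the measured compounds named here, the same replacement gave a 2.5-fold higher number from compound 2 to compound 3 (0.40 log units; beyond the scatter) and is the closest guide, though it is only a single modest step. The change from hydroxy gave a 2.0-fold higher number from compound 1 to compound 2 (0.30 log units; within the scatter) for amino and a 5.0-fold higher number from compound 1 to compound 3 (0.70 log units; beyond the scatter) for methylamino. Going by the values given here, no dimethylamino compound has been measured. A modest upward step is therefore expected, estimated as a 2.0-fold higher number from compound 3 to compound 4 (0.30 log units; within the scatter) on this one precedent. Compound 4 is expected at an estimated 200 nM with a likely range from 80 nM to 500 nM in this measurement.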

Compound 4, half-maximal inhibitory concentration: 130 nM
Beside the measured number, compound 4's estimate is 1.5-fold (0.19 log units) above it, within the range that was stated.
By their numbers in this assay, from the lowest: compounds 1 and 2 (each within the scatter of the next); then compounds 3 and 4 (each within the scatter of the next).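

In this assay a second methyl on the amine nitrogen gives no change beyond the scatter (a 1.3-fold higher number from compound 3 to compound 4 (0.11 log units; within the scatter)), unlike the first methyl (a 2.5-fold higher number from compound 2 to compound 3 (0.40 log units; beyond the scatter)). Dimethylamino nevertheless stays apart from both the amino group (a 3.3-fold higher number from compound 2 to compound 4 (0.51 log units; beyond the scatter)) and the hydroxy group (a 6.5-fold higher number from compound 1 to compound 4 (0.81 log units; beyond the scatter)), so on these four compounds the hydroxy and amino groups sit together, and the methylamino and dimethylamino groups sit together. Nothing measured here accounts for this difference. From the compounds shown here alone, whether a ring amine such as piperidine, a carboxylic acid or a longer chain at this position would follow the same order remains open.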